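A Fluorine Added to the Benzamide of Compound 2

A few compounds are considered here, and "the series" means these few. Any claim that something is new, unique, unknown or untested is made for them only; others in the source may bear on it.

Of the compounds shown here, two have been tested in a functional assay on MDA-MB-468 cells (Homo sapiens) for antiproliferative activity; on this read-out higher numbers stand for weaker inhibition of growth and lower numbers for stronger inhibition of growth. Compound 1, `COc1cccc(-c2nn(-c3ccccc3)cc2-c2ccnc(NCCNC(=O)Nc3cccc(C(F)(F)F)c3)c2)c1`, gives 1700 nM in this assay. Compound 2, `O=C(NCCCNc1cc(-c2cn(-c3ccccc3)nc2-c2cccc(O)c2)ccn1)c1ccccc1`, gives 1380 nM in this assay. The two numbers sit side by side: the gap between compound 2 and compound 1 lies within the usual scatter of repeated measurements, so neither can be called more or less potent than the other on this evidence.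

Compound 3, `O=C(NCCCNc1cc(-c2cn(-c3ccccc3)nc2-c2cccc(O)c2)ccn1)c1ccc(F)cc1`, is the next member. It differs from compound 2 in a single spot: fluoro in place of hydrogen on an aromatic carbon. Among the compounds with values here, the change sits on the benzoyl group at the end of the amide, para to a large group, and no measured pair in this set shows what such a swap does here. With nothing to point in either direction, the expectation for the step in this assay is none beyond the scatter, so compound 3 is expected to show a 1.1-fold lower number from compound 2 to compound 3 (0.03 log units; within the scatter) against compound 2. On that basis compound 3 is estimated at 1300 nM in this assay, with a range from 600 nM to 2800 nM.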

Compound 3, concentration for 50% growth inhibition: 1590 nM
The estimate for compound 3 lay 1.2-fold (0.09 log units) below the measured number, and the stated range covers the measured number.
By their numbers in this assay, from the lowest: compounds 2, 3 and 1 (each within the scatter of the next).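

Fluoro in place of hydrogen on the benzoyl group is the first change in this series that can be read on its own, and in this assay it gives a 1.2-fold higher number from compound 2 to compound 3 (0.06 log units; within the scatter). This step lies within the scatter, so going from phenyl to 4-fluorophenyl at this position, para to a large group, leaves no effect that can be told apart from the spread of repeated measurements. The data shown offer no independent measurement that would help interpret this outcome.

A single fluorine adds only one heavy atom, so this pair cannot say whether the position would tolerate a larger or quite different group, such as methoxy, an amine or a carboxylic acid, in the same place. Also open, on these data alone, is whether fluoro on another carbon of the same ring, or a longer chain leading to the benzamide, would move the number beyond the scatter.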